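The source may report more compounds than this note shows. Statements on the series, on what has been measured and on what is new or still open speak of the compounds shown alone.

Series notes, values in a functional assay on HL-60 cells (Homo sapiens) for inhibition, read by MTT assay, with a stated time of 48 h, tested at 10 uM; a lower number here means less inhibition of growth, a higher number more inhibition of growth at the concentration tested:

- compound 1 `CCN(CC)Cc1c(O)c([C@H]2CCN(C)C[C@H]2O)c2oc(C)cc(=O)c2c1O`: 47%
- compound 2 `Cc1cc(=O)c2c(O)c(CN3CCCC3CO)c(O)c([C@H]3CCN(C)C[C@H]3O)c2o1`: 33%
- compound 3 `Cc1cc(=O)c2c(O)c(CN(C(C)C)C(C)C)c(O)c([C@H]3CCN(C)C[C@H]3O)c2o1`: 21%

Compound 3 stands lowest of the three, with compound 2 the nearest and compound 1 the furthest. The next compound to be tested in this assay is compound 4 `Cc1cc(=O)c2c(O)c(CN3CCCC3C(=O)O)c(O)c([C@H]3CCN(C)C[C@H]3O)c2o1`. It carries 2-carboxypyrrolidin-1-yl in place of diisopropylamino on a saturated chain carbon bound to an aromatic carbon.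

Two measured steps change the same group at the same place. The closer case is a number 12 percentage points lower from compound 2 to compound 3 (beyond the scatter), since 2-(hydroxymethyl)pyrrolidin-1-yl also has the five-membered ring. The other is a number 26 percentage points lower from compound 1 to compound 3 (beyond the scatter), which involves diethylamino and has no ring. Read in reverse, both suggest that leaving diisopropylamino raises the number. However, no measured compound carries 2-carboxypyrrolidin-1-yl, so the carboxy group itself is untested, and only three values support the trend. Among the compounds with values here, a small upward step is therefore expected, probably smaller than the one suggested by compound 2 at 33%, and it may not clear the scatter. The estimated step is a number 8 percentage points higher from compound 3 to compound 4 (within the scatter).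

The expected value for compound 4 is 29%, with an estimated range from 12% to 45%.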

Compound 4, percent growth inhibition at one concentration: 16%
The estimate for compound 4 lay 13 percentage points above the measured number; the measured number falls inside the stated range.
By their numbers in this assay, from the lowest: compounds 4 and 3 (each within the scatter of the next); then compound 2; then compound 1.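

In this assay, carboxy in place of hydroxymethyl on a saturated ring carbon gives a number 17 percentage points lower from compound 2 to compound 4 (beyond the scatter), so at this place the five-membered ring does not by itself hold the number near that of compound 2, and the group carried on the ring carbon counts. Within the data shown here, the exchange of (diisopropylamino)methyl for (2-carboxypyrrolidin-1-yl)methyl gives a number 5 percentage points lower from compound 3 to compound 4 (within the scatter), which leaves these two compounds unordered even though one group has a ring and the other has none, so the rise that the earlier steps pointed to on leaving diisopropylamino does not hold for every group that enters. The change from diethylamino to 2-carboxypyrrolidin-1-yl gives a number 31 percentage points lower from compound 1 to compound 4 (beyond the scatter), the largest step in the series, and diethylamino remains the group with the highest number among these four compounds, its steps to all the others lying beyond the scatter.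

Open, from the compounds shown here alone, is where a methyl ester or a primary amide on that ring carbon would fall relative to hydroxymethyl and carboxy, and whether a piperidine ring would behave like the pyrrolidine ring. Nothing available explains why these groups differ at this place.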